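A few compounds are considered here, and "the series" means these few. Any claim that something is new, unique, unknown or untested is made for them only; others in the source may bear on it.

This piece follows a small series of compounds tested in a functional assay on P388 cells (Mus musculus) for inhibition, tested at 100 uM; on this read-out lower numbers stand for a weaker effect and higher numbers for a stronger effect at the one concentration tested. Compound 1, with the structure `Cc1ccc(S(=O)(=O)n2cc(-c3cc(C(F)(F)F)ccn3)c3ccccc32)cc1`, gives 49.9%. Compound 2, with the structure `Cc1ccc(S(=O)(=O)n2cc(-c3cc(C(F)(F)F)cc(-c4cn(S(=O)(=O)c5ccc(C)cc5)c5ccccc45)n3)c3ccccc32)cc1`, gives 14.7%, and compound 3, with the structure `Cc1ccc(S(=O)(=O)n2cc(-c3cc(C(F)(F)F)cc(-c4cn(S(=O)(=O)c5ccc(C)cc5)c5cc(Br)ccc45)n3)c3ccc(Br)cc32)cc1`, gives 8.9%.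

Compound 3 has the lowest of the three numbers, but its distance from compound 2 lies within the usual scatter of this kind of measurement, so the two cannot be told apart; only compound 1 stands clearly higher, beyond the scatter.

Compound 4, with the structure `Cc1ccc(S(=O)(=O)n2cc(-c3cc(C(F)(F)F)c(C#N)c(-c4cn(S(=O)(=O)c5ccc(C)cc5)c5cc(Br)ccc45)n3)c3ccc(Br)cc32)cc1`, has not yet been measured. It differs from compound 3 in one place: cyano in place of hydrogen on an aromatic carbon. Within the data shown here, no pair among the measured compounds differs in exactly one place, so there is no measured step of comparable size to lean on. The change is small, and the starting number for compound 3 is already near the bottom of the scale, so the expected step from compound 3 to compound 4 is a number 1.1 percentage points higher from compound 3 to compound 4 (within the scatter), which is no change beyond the scatter. Compound 4 is therefore expected to give about 10% in this assay, with a likely range from 0% to 28%.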

Compound 4, a percentage reported as inhibition, at one concentration (the size of the read-out at that concentration, not a potency): 1.3%
For compound 4 the middle estimate is 8.7 percentage points above the measured one; the range from low to high includes it.
By their numbers in this assay, from the lowest: compounds 4, 3 and 2 (each within the scatter of the next, the first and the last beyond it); then compound 1.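

Placing a cyano group on this aromatic carbon, ortho to a trifluoromethyl group and two atoms from the ring nitrogen, is the only single change shown in the series, and in this assay it comes with a number 7.6 percentage points lower from compound 3 to compound 4 (within the scatter) so the two compounds cannot be told apart. At this one concentration, compound 3 gives 8.9% and compound 4 gives 1.3% so both sit near the bottom of the scale, where the added nitrile brings no recovery of the read-out but where a further loss would also have little room to show. No measured property of either compound is available to explain this result.

Going by these compounds, whether any group on this carbon can lift the number well clear of the scatter stays open, and an amine, a carboxylic acid or a longer chain in the same place would test that against compound 3. On these data alone, it is also open whether cyano would behave the same way on compound 2, which carries no bromine, where the starting number leaves a similarly small margin.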